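The source may hold more compounds than are shown below. What is called first, only, known or untested is meant among the compounds shown, and "the series" means these compounds.

compound 1 `C[C@H](NC(=O)COc1cc(C(F)(F)F)c2c(-c3ccccn3)nn(C)c2n1)c1ccccc1` gives 40000 nM
compound 2 `Cc1ccc([C@H](C)NC(=O)COc2cc(C)c3c(-c4ncccn4)nn(C)c3n2)cc1` gives 43000 nM
compound 3 `Cc1nn(C)c(C)c1C(C)NC(=O)COc1cc(C(F)F)c2c(C3CC3)nn(C)c2n1` gives 657000 nM

These three numbers all come from a physicochemical assay for solubility, measured as thermodynamic solubility, at pH 6.8; on this read-out lower numbers stand for lower solubility and higher numbers for higher solubility. Compound 3 stands highest of the three at 657000 nM, and its gap to each of the other two lies beyond the usual scatter of repeated measurements. Compound 1 and compound 2 lie within that scatter of each other. No two of the three differ in just one place, so no clean single-change comparison is available.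

The next molecule, compound 4 `Cc1nn(C)c(C)c1C(C)NC(=O)COc1cc(C(F)F)c2c(-c3ccccc3)nn(C)c2n1`, is compound 3 with one group exchanged: phenyl in place of cyclopropyl on an aromatic carbon.

The step expected in this assay is downward and beyond the scatter. The only hint is indirect. Compound 1, at 40000 nM, and compound 2, at 43000 nM, both carry a six-membered aromatic ring on the matching carbon and both sit well under compound 3. They also differ from compound 3 elsewhere, so this hint is weak and the range must stay wide.

The estimated value for compound 4 is 120000 nM, with an expected range of 30000 nM to 400000 nM. Put as a change, the expected move is a 5.5-fold lower number from compound 3 to compound 4 (0.74 log units; beyond the scatter).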

Compound 4, solubility: 248000 nM
For compound 4 the middle estimate is 2.1-fold (0.32 log units) below the measured one, within the range that was stated.
By their numbers in this assay, from the lowest: compounds 1 and 2 (each within the scatter of the next); then compound 4; then compound 3.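

In this assay, going by these compounds alone, phenyl in place of cyclopropyl on an aromatic carbon gives a 2.6-fold lower number from compound 3 to compound 4 (0.42 log units; beyond the scatter), and this is the first pair in the set that differs in one place only. The earlier compounds shown here gave only an indirect view of this position, whereas this pair ties a modest but real downward step to this single exchange on an otherwise unchanged molecule. The exchange replaces a three-membered non-aromatic ring with a larger six-membered aromatic ring, and nothing here offers an measured explanation for the step.

This one pair cannot separate ring size from aromatic character, since both change together, and it cannot show whether the same step would appear with the other groups found elsewhere in compounds 1 and 2. It also leaves open how the number would respond to a quite different group on this carbon, such as an amine, a morpholine ring or a carboxylic acid, which would show how far this position can move the read-out.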